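Trimming the 2,4,6-trihydroxyphenyl group of compound 2

The compounds below may be only part of what the source reports. "The series", "measured", "known", "first", "only" and "open" are said of these compounds alone.

In a functional assay on DU-145 cells (Homo sapiens) for inhibition, read by trypan blue exclusion, with a stated time of 96 h (on this read-out lower numbers stand for stronger inhibition of growth and higher numbers for weaker inhibition of growth), compound 1 `O=C(/C(=C\c1c(O)cc(O)cc1O)SCc1ccc(Cl)cc1)c1ccc(Cl)cc1` gives > 100000 nM, which is a limit of the assay and not a number. Within the data shown here, compound 2 `O=C(/C(=C\c1c(O)cc(O)cc1O)SCc1ccc(Cl)c(Cl)c1)c1ccc(Cl)cc1`, at 25000 nM, holds the only actual number so far. Among the measured compounds shown here, the one measured step, an at least 4.0-fold lower number from compound 1 to compound 2 (0.60 log units; beyond the scatter), is chloro in place of hydrogen on an aromatic carbon, and it starts from that limit. Compound 3 `O=C(/C(=C\c1ccc(O)cc1)SCc1ccc(Cl)c(Cl)c1)c1ccc(Cl)cc1` differs from compound 2 at another place: 4-hydroxyphenyl in place of 2,4,6-trihydroxyphenyl on a double-bonded chain carbon bound to a double-bonded chain carbon. For the measured compounds named here, no measured step touches this group, so no clear shift is expected in this assay, and the estimated step is a 1.3-fold lower number from compound 2 to compound 3 (0.10 log units; within the scatter). For compound 3 the expected value is 20000 nM, with an estimated range of 5000 nM to 80000 nM.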

Compound 3, concentration for 50% growth inhibition: 1000 nM
Compound 3: the middle estimate sits 20-fold (1.30 log units) above what was measured; measured number outside the range, below it.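

Replacing 2,4,6-trihydroxyphenyl with 4-hydroxyphenyl on a double-bonded chain carbon bound to a double-bonded chain carbon gives a 25-fold lower number from compound 2 to compound 3 (1.40 log units; beyond the scatter) in this assay, so the full trihydroxy pattern is not needed for growth inhibition in this series. This is also the first step read between two actual numbers, as the earlier step starts at compound 1, whose value is a limit of the assay: the limit of > 100000 nM in this assay, at which 1 of the 3 values shown sits.

On these data alone, it remains open whether the gain tracks the hydroxyl groups removed or the one retained; a plain phenyl, a methoxyphenyl or an aminophenyl group at this place would separate the two. As far as these compounds go, whether the added chloro still matters alongside 4-hydroxyphenyl also remains open.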